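Adding an Amino Group: Expecting Weaker Growth Inhibition

This account rests on a few compounds, and the source may have more. Where it says the series, first, only, none or still open, it means among the compounds named here.

Of the compounds shown here, three have been measured in a functional assay on NCI-H322M cells (Homo sapiens) for cytotoxicity, read by sulforhodamine B assay, with a stated time of 48 h; a lower number here means a stronger inhibitor of growth, a higher number a weaker inhibitor of growth. Compound 1 `ClCc1ccccc1Cn1cnc2c(Cl)nc(Cl)nc21` gives 3270 nM, compound 2 `Nc1nc(Cl)c2ncn(Cc3ccc(CCl)cc3)c2n1` gives 42700 nM, and compound 3 `ClCc1ccccc1Cn1cnc2c(Cl)ncnc21` gives 13800 nM. Compound 3 therefore stands second highest of the three numbers, with compound 1 lower and compound 2 higher, both gaps beyond the scatter. Among the measured compounds shown here, the one step that joins two measured compounds differing in a single place, a 4.2-fold higher number from compound 1 to compound 3 (0.63 log units; beyond the scatter), shows that removing a chloro group from the shared core weakens growth inhibition by a modest but real margin.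

Compound 4 `Nc1nc(Cl)c2ncn(Cc3ccccc3CCl)c2n1` is the next to be measured. It differs from compound 3 by amino in place of hydrogen on an aromatic carbon. For the measured compounds named here, no measured pair shows this exact change, so no step can be read off directly. Compound 2 carries the same amino and chloro groups as compound 4 and differs only in the placement of its chloromethyl group; in this assay compound 2 gives 42700 nM, a higher number than compound 3. On that basis compound 4 is expected to give a higher number than compound 3, an estimated step of a 1.8-fold higher number from compound 3 to compound 4 (0.26 log units; within the scatter). The estimate for compound 4 is 25000 nM, with a likely range from 8000 nM to 80000 nM.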

Compound 4, concentration for total growth inhibition: 29500 nM
Beside the measured number, compound 4's estimate is 1.2-fold (0.07 log units) below it, within the range that was stated.
By their numbers in this assay, from the lowest: compound 1; then compound 3; then compounds 4 and 2 (each within the scatter of the next).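

In this assay, the carbon between two ring nitrogen atoms can now be compared with three different groups on an otherwise unchanged structure, and amino in place of hydrogen gives a 2.1-fold higher number from compound 3 to compound 4 (0.33 log units; beyond the scatter). Amino in place of chloro on the same carbon gives a 9.0-fold higher number from compound 1 to compound 4 (0.96 log units; beyond the scatter), a larger step than the change from hydrogen, so among these three compounds the number rises from chloro to hydrogen to amino. These values show the size and direction of each change, but nothing available explains why growth inhibition shifts in this way.

On these data alone, three groups are too few to show a general trend at this carbon, so it remains open where a methoxy group, a fluoro group or a dimethylamino group would fall relative to chloro, hydrogen and amino. It is also unclear whether the same order would hold with the chloromethyl group placed differently on the benzene ring, since these three comparisons all share a single arrangement.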